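The source may report more compounds than this note shows. Statements on the series, on what has been measured and on what is new or still open speak of the compounds shown alone.

Measured so far in an ADME assay on HEL cells (Homo sapiens) for cytotoxicity, with a stated time of 3 days; a higher number here means that more compound is tolerated, a lower number that less compound is tolerated:
compound 1 `CCC1(Cc2ccccc2)OS(=O)(=O)C=C1OS(=O)(=O)c1ccc(C)cc1` gives 400000 nM.
compound 2 `CCC1(Cc2ccccc2)OS(=O)(=O)C=C1OCc1ccc(Cl)cc1` is recorded only as a limit of the assay, >= 50000 nM.
compound 3 `CCC1(CC)OS(=O)(=O)C=C1OCc1ccccc1` is likewise recorded only as a limit of the assay, > 400000 nM.

Compound 2 thus has no number of its own in this assay; it stands at the limit of >= 50000 nM in this assay, at which 1 of the 3 values shown sits. Of the other two values, compound 1 is a number, while compound 3 stands at the limit of > 400000 nM in this assay, at which 1 of the 3 values shown sits. The three benzyl-type ethers and sulfonates of the shared core therefore show little tolerance lost at the concentrations tested, and compound 2 cannot be placed against compound 1 or compound 3 beyond the fact that its limit lies lower than theirs.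

Compound 4 `CCC1(Cc2ccccc2)OS(=O)(=O)C=C1OCc1ccc(C)cc1` is the untested member. It differs from compound 2 by methyl in place of chloro on an aromatic carbon. For the measured compounds named here, no step between measured compounds is available to calibrate this change in this assay. Compound 4 is expected to remain well tolerated, with a step that the limit leaves unreadable from compound 2 to compound 4 that is estimated to be none beyond the scatter. Compound 4 is estimated at 200000 nM, within 50000 nM to 500000 nM.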

Compound 4, minimum cytotoxic concentration: >= 16000 nM
Compound 4 gave a limit, no number (the forecaster's own chance of this, stated with the estimate: 50%); the middle value does not contradict the limit.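

In this assay compound 4 is recorded only as a limit, >= 16000 nM. For the compounds shown here, compound 2 is likewise only a limit, >= 50000 nM, so no step between compound 2 and compound 4 can be read. The compounds shown leave open whether methyl in place of chloro on an aromatic carbon changes tolerance at all.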